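Swapping the Group on a Ring Nitrogen

The compounds below may be only part of what the source reports. "The series", "measured", "known", "first", "only" and "open" are said of these compounds alone.

- Compound 1 `CCN1C[C@H](C(=O)Nc2ccc(Cl)cc2)[C@@H](c2ccc(/C=C/C(=O)Nc3ccccc3N)cc2)C1`: 12 mL/min/kg
- Compound 2 `CCNC(=O)N1C[C@H](C(=O)Nc2ccc(Cl)cc2)[C@@H](c2ccc(/C=C/C(=O)Nc3ccccc3N)cc2)C1`: 9 mL/min/kg
- Compound 3 `Nc1ccccc1NC(=O)/C=C/c1ccc([C@H]2CN(c3ncccn3)C[C@@H]2C(=O)Nc2ccc(Cl)cc2)cc1`: not yet measured

Both numbers come from an in vitro ADME assay on microsomes from liver (Homo sapiens) for pharmacokinetics, read by LC-MS, with a stated time of 10 min, tested at 1 uM; a lower number here means slower removal, a higher number faster removal of the compound. In this assay compound 2 gives 9 mL/min/kg, and this sits within the usual scatter of compound 1 at 12 mL/min/kg. The two compounds therefore cannot be told apart on this measure.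

Compound 3 keeps the shared core and changes only the group on the ring nitrogen, with pyrimidin-2-yl in place of ethylcarbamoyl on an amine nitrogen in a ring.

Within the data shown here, only one measured step bears on this place. That step, a 1.3-fold lower number from compound 1 to compound 2 (0.12 log units; within the scatter), exchanged ethyl for ethylcarbamoyl on the same nitrogen. Among the measured compounds shown here, it is small, but it is a single step, and no measured compound carries a pyrimidin-2-yl group, so the evidence is thin. With nothing pointing in either direction, no change beyond the scatter is expected.

The expected step is a 1.2-fold higher number from compound 2 to compound 3 (0.09 log units; within the scatter). For compound 3 the estimated clearance is 11 mL/min/kg, with an expected range from 5 mL/min/kg to 22 mL/min/kg.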

Compound 3, clearance: 11 mL/min/kg
Compound 3: the middle estimate sits on the measured number at the digits printed, and the stated range covers the measured number.
By their numbers in this assay, from the lowest: compounds 2, 3 and 1 (each within the scatter of the next).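

Among these compounds, the ring nitrogen has now carried three different groups, and pyrimidin-2-yl is the first of them to bring a ring, a six-membered aromatic one with 2 hetero atoms, while also dropping the hydrogen-bond donor of ethylcarbamoyl. Even so, this assay shows a 1.2-fold higher number from compound 2 to compound 3 (0.09 log units; within the scatter) for this exchange and a 1.1-fold lower number from compound 1 to compound 3 (0.04 log units; within the scatter) for the exchange with ethyl, so neither comparison separates the compounds. Across these three compounds, then, a small chain, a chain with a carbonyl and an aromatic ring on this nitrogen all give numbers that cannot be told apart, and no accompanying measurement offers an explanation for this.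

As far as these compounds go, whether a carboxylic acid, a primary amine on a longer chain or a larger fused aromatic ring on this nitrogen would move the number beyond the scatter remains open. From the compounds shown here alone, all three compounds also keep the (4-chlorophenyl)carbamoyl group on the ring, so it is equally open whether the same flat picture would hold with a different group in that place.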